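A Thiophene Shift on a Shared Core

A few compounds are considered here, and "the series" means these few. Any claim that something is new, unique, unknown or untested is made for them only; others in the source may bear on it.

Of the compounds shown here, two have been measured in an assay on isolated protein for inhibition of DNA topoisomerase 1 (Homo sapiens), with a stated time of 30 min, tested at 20 uM; on this read-out higher numbers stand for a stronger effect at the one concentration tested and lower numbers for a weaker effect. Compound 1 `Oc1ccc(-c2cc(-c3cccs3)cc(-c3cccc(O)c3)n2)cc1` gives 1.1%, and compound 2 `Oc1ccc(-c2cc(-c3cccs3)cc(-c3ccc(O)cc3)n2)cc1` gives 0.9%. Among the compounds with values here, the single measured step, a number 0.2 percentage points lower from compound 1 to compound 2 (within the scatter), alters only a hydroxyphenyl group and leaves the read-out essentially where it was. On these two numbers compound 2 stands beside compound 1, the gap between them lying within the scatter, so neither can be called the weaker or the stronger.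

Compound 3 `Oc1ccc(-c2cc(-c3ccsc3)cc(-c3ccc(O)cc3)n2)cc1` is the compound not yet measured. Its difference from compound 2 is thiophen-3-yl in place of thiophen-2-yl on an aromatic carbon. Within the data shown here, no measured step touches the thiophene ring, so nothing measured bears directly on this change; the only step available concerns the hydroxyphenyl groups and was small. Among the measured compounds shown here, both measured compounds sit close to zero inhibition, and that is the only guide. The expected step is therefore a number 0.6 percentage points higher from compound 2 to compound 3 (within the scatter), which means nothing beyond the scatter. The estimate for compound 3 is 1.5%, within a range from -6% to 10%.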

Compound 3, a percentage reported as inhibition, at one concentration (the size of the read-out at that concentration, not a potency): 7.5%
The estimate for compound 3 lay 6 percentage points below the measured number; the measured number falls inside the stated range.
By their numbers in this assay, from the lowest: compounds 2, 1 and 3 (each within the scatter of the next).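

Within the data shown here, this is the first measured step that touches the thiophene ring, at the aromatic carbon opposite the ring nitrogen, and it swaps thiophen-2-yl for thiophen-3-yl with the same atoms joined differently. In this assay, that change gives a number 6.6 percentage points higher from compound 2 to compound 3 (within the scatter), so on this read-out the two attachments of the thiophene ring cannot be told apart, just as the earlier step between the hydroxyphenyl groups could not. No other measurement bearing on this result is available.

What remains open is whether anything at this position can move the read-out beyond the scatter, since the only groups shown there are the two thiophenes; a quite different group on the same carbon, such as an amine, a carboxylic acid or a longer alkyl chain, would test that directly. Going by these compounds, it also remains open whether thiophen-3-yl gives a similar number when paired with the 3-hydroxyphenyl group of compound 1, a combination that would show whether the two single changes on the shared core act independently of each other.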